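Solubility at low pH across an amine-linked aryl series

The source may hold more compounds than are shown below. What is called first, only, known or untested is meant among the compounds shown, and "the series" means these compounds.

Measured compounds:
- compound 1, `FC(F)(F)c1cccc(-c2nc3cnc(Nc4cnccn4)cc3[nH]2)c1`, 155000 nM in a physicochemical assay for solubility, using the shake flask method, measured as kinetic solubility, with a stated time of 20 h, at pH 2; a lower number here means a less soluble compound, a higher number a more soluble compound
- compound 2, `Fc1ccc(-c2nc3cnc(Nc4ccccn4)cc3[nH]2)cc1C(F)(F)F`, 7000 nM in this assay
- compound 3, `Fc1ccc(-c2nc3cnc(Nc4ccc(C(F)(F)F)cn4)cc3[nH]2)cc1F`, 6000 nM in this assay

Compound 1 stands highest of the three numbers in this assay. Its nearest neighbour is compound 2, which sits well below it, beyond the scatter; compound 3 sits furthest, also beyond the scatter. Compounds 2 and 3 lie within the scatter of each other, so nothing is said about their order.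

Compound 4, `O=C(O)c1ccnc(Nc2cc3[nH]c(-c4cccc(C(F)(F)F)c4)nc3cn2)c1`, has not been measured in this assay. It differs from compound 1 in one place: 4-carboxypyridin-2-yl in place of pyrazin-2-yl on a nitrogen on an aromatic ring. The shared core and the trifluoromethyl-bearing aryl ring of compound 1 are kept unchanged.

Within the data shown here, no step between measured compounds separates the effect of this exchange from other changes, so the expectation rests on the whole set. The two measured compounds that carry a pyridin-2-yl group rather than a pyrazin-2-yl group, compound 2 and compound 3, both give numbers far below compound 1, but each also carries a different aryl ring, so the comparison is indirect. A downward step of moderate size is expected for compound 4, as a 3.1-fold lower number from compound 1 to compound 4 (0.49 log units; beyond the scatter), with a wide range that does not rule out a number within the scatter of compound 1. The estimate for compound 4 in this assay is 50000 nM, within 10000 nM to 200000 nM.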

Compound 4, solubility: < 5000 nM
Compound 4: a limit, no number (the forecaster's own chance of this, stated with the estimate: 5%); middle value at least 10-fold (1.00 log units) from the limit.
By their numbers in this assay, from the lowest: compounds 3 and 2 (each within the scatter of the next); then compound 1. At a limit, below all of these: compound 4.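

In this assay, 4-carboxypyridin-2-yl in place of pyrazin-2-yl on a nitrogen on an aromatic ring gives an at least 31-fold lower number from compound 1 to compound 4 (1.49 log units; beyond the scatter), with the shared core and the trifluoromethyl-bearing aryl ring unchanged. Among these compounds, this is the first step in the set that isolates this position, as the earlier compounds differ from compound 1 in more than one place, and it shows that this single exchange is enough for a large drop from the high value of compound 1. The value of compound 4 is a limit and not a number: the limit of < 5000 nM in this assay, at which 1 of the 4 values shown sits.

The step bundles two changes, the loss of a ring nitrogen and the arrival of a carboxylic acid, and the compounds shown do not separate them; an unsubstituted pyridin-2-yl group on the core of compound 1 would isolate the ring change. As far as these compounds go, it also stays open whether the drop depends on the carboxylic acid itself, which a methyl ester, a primary amide or an aminomethyl group at the same place on the pyridine ring would test.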